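The compounds below may be only part of what the source reports. "The series", "measured", "known", "first", "only" and "open" are said of these compounds alone.

Within the data shown here, in a functional assay on cells (Endothelial cell, Homo sapiens) for inhibition (a higher number here means a weaker inhibitor, a lower number a stronger inhibitor), compound 2 `CC(=O)Nc1cc(CO[C@@H]2O[C@@H](COC(=O)c3ccccc3)[C@H](O[C@H]3OC4CO[C@@H](c5ccc(Cl)cc5)OC4[C@H](O)[C@@H]3O)[C@H](O)[C@@H]2O)ccc1Cl` gives 324 nM, the lower of the two numbers measured so far; compound 1 `CC(=O)Nc1cc(CO[C@@H]2O[C@@H](COC(=O)c3ccccc3)[C@H](O[C@H]3OC4CO[C@@H](c5ccccc5)OC4[C@H](O)[C@@H]3O)[C@H](O)[C@@H]2O)ccc1Cl` gives 923 nM, and the only change between them, chloro in place of hydrogen on an aromatic carbon, brought a 2.8-fold lower number from compound 1 to compound 2 (0.45 log units; beyond the scatter). Compound 3 `CC(=O)Nc1cc(CO[C@@H]2O[C@@H](COC(=O)c3ccccc3)[C@H](O[C@H]3OC4CO[C@@H](c5ccc([N+](=O)[O-])cc5)OC4[C@H](O)[C@@H]3O)[C@H](O)[C@@H]2O)ccc1Cl` differs from compound 2 by nitro in place of chloro on an aromatic carbon. Among the measured compounds shown here, no measured step swaps one group for another at this carbon, so that earlier step offers only indirect guidance. A change of a 1.0-fold lower number from compound 2 to compound 3 (0.01 log units; within the scatter) is expected, within the scatter. The estimate for compound 3 in this assay is 320 nM, between 120 nM and 850 nM.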

Compound 3, half-maximal inhibitory concentration: 368 nM
Beside the measured number, compound 3's estimate is 1.2-fold (0.06 log units) below it; measured number inside the range.
By their numbers in this assay, from the lowest: compounds 2 and 3 (each within the scatter of the next); then compound 1.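

In this assay, the swap of 4-chlorophenyl to 4-nitrophenyl gives a 1.1-fold higher number from compound 2 to compound 3 (0.06 log units; within the scatter), so chloro and nitro cannot be told apart here, even though nitro brings more heavy atoms and hydrogen-bond acceptors. Measured against hydrogen, nitro also gives a 2.5-fold lower number from compound 1 to compound 3 (0.40 log units; beyond the scatter), showing that the lower number seen with chloro is not unique to that group. Nothing available explains why these two groups match. As far as these compounds go, whether an amine or a carboxylic acid on this carbon would give a similar number remains open.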